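Piperazine cap exchange in a weak serotonin-receptor series

The compounds below may be only part of what the source reports. "The series", "measured", "known", "first", "only" and "open" are said of these compounds alone.

Measured so far:
compound 1, `CCc1nc2c(C(=O)NCC3CCN(CC(O)CN4CCN(S(C)(=O)=O)CC4)CC3)cccc2[nH]1`, 79400 nM in an assay on isolated protein for binding affinity to 5-hydroxytryptamine receptor 3A (Homo sapiens); on this read-out higher numbers stand for weaker inhibition and lower numbers for stronger inhibition
compound 2, `CS(=O)(=O)N1CCN(CC(O)CN2CCC(CNC(=O)c3cccc4[nH]c(C5CC5)nc34)CC2)CC1`, 50100 nM in this assay
compound 3, `CC(C)c1nc2c(C(=O)NCC3CCN(CCN4CCN(S(C)(=O)=O)CC4)CC3)cccc2[nH]1`, 100000 nM in this assay

All three numbers lie within the scatter of one another; compound 3 cannot be told apart from compound 1 or compound 2 on this read-out. Among the measured compounds shown here, the only measured step, a 1.6-fold lower number from compound 1 to compound 2 (0.20 log units; within the scatter), concerns the group on the aromatic carbon, not the piperazine end.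

Compound 4, `CC(=O)N1CCN(CCN2CCC(CNC(=O)c3cccc4[nH]c(C(C)C)nc34)CC2)CC1`, differs from compound 3 by acetyl in place of methylsulfonyl on an amine nitrogen in a ring. For the measured compounds named here, no measured step touches this position, so there is nothing to carry over. With all three known values so close, the step of a 1.1-fold lower number from compound 3 to compound 4 (0.05 log units; within the scatter) is expected to stay within the scatter. Compound 4 is estimated at 90000 nM, between 35000 nM and 250000 nM.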

Compound 4, inhibition constant: 39800 nM
Compound 4: middle estimate off by 2.3-fold (0.35 log units), on the high side; low and high end bracket the measured number.
By their numbers in this assay, from the lowest: compounds 4, 2, 1 and 3 (each within the scatter of the next, the first and the last beyond it).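

Among the compounds shown here, the exchange at this ring nitrogen gives the only step beyond the scatter so far: a 2.5-fold lower number from compound 3 to compound 4 (0.40 log units; beyond the scatter), a modest step in this assay. The piperazine end therefore registers on this read-out, with acetyl reading lower than methylsulfonyl. No supporting data bear on the origin of this step.

As far as these compounds go, whether the step carries over to the chain of compound 1 and compound 2 remains open. Also open, from the compounds shown here alone, is how a free amine or a longer acyl chain on this nitrogen would read.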